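A few compounds are considered here, and "the series" means these few. Any claim that something is new, unique, unknown or untested is made for them only; others in the source may bear on it.

Three compounds share one core and differ only in the aromatic ring attached to it. Compound 1 `Cc1ccccc1-c1c(C)nn(-c2nc(-c3ccc(Cl)c(Cl)c3)c(SC(C)C)s2)c1C(=O)O` carries a 2-methylphenyl group there. In a functional assay on BJAB cells (Homo sapiens) for antiproliferative activity, with a stated time of 4 days (a higher number here means that more compound is needed for the effect, a lower number that less compound is needed), compound 1 gives 5500 nM, the second highest of the three numbers. Compound 2 `Cc1nn(-c2nc(-c3ccc(Cl)c(Cl)c3)c(SC(C)C)s2)c(C(=O)O)c1-c1cccc(F)c1` carries a 3-fluorophenyl group, and in this assay compound 2 gives 900 nM; the step is a 6.1-fold lower number from compound 1 to compound 2 (0.79 log units; beyond the scatter). Compound 3 `Cc1nn(-c2nc(-c3ccc(Cl)c(Cl)c3)c(SC(C)C)s2)c(C(=O)O)c1-c1cccc(C(F)(F)F)c1` carries a 3-(trifluoromethyl)phenyl group; in this assay compound 3 gives 22000 nM, and the step is a 4.0-fold higher number from compound 1 to compound 3 (0.60 log units; beyond the scatter). Between the two substituted rings the step is a 24-fold higher number from compound 2 to compound 3 (1.39 log units; beyond the scatter).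

Compound 4 `Cc1nn(-c2nc(-c3ccc(Cl)c(Cl)c3)c(SC(C)C)s2)c(C(=O)O)c1-c1ccccc1[N+](=O)[O-]` has not yet been measured. It differs from compound 1 in one place: nitro in place of methyl on an aromatic carbon. Among the compounds with values here, no measured step exchanges these two groups at this position, so the only guide is that altering the group on this ring moved the number in both directions, downward from compound 1 to compound 2 and upward from compound 1 to compound 3. A step of modest size is therefore the reasonable expectation, with no firm case for either direction, and a wide range. For compound 4 the expected step is a 1.5-fold higher number from compound 1 to compound 4 (0.16 log units; within the scatter). In this assay compound 4 is estimated to give 8000 nM, within a range from 2000 nM to 30000 nM.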

Compound 4, half-maximal effective concentration: 4700 nM
For compound 4 the middle estimate is 1.7-fold (0.23 log units) above the measured one; low and high end bracket the measured number.
By their numbers in this assay, from the lowest: compound 2; then compounds 4 and 1 (each within the scatter of the next); then compound 3.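

Exchanging methyl for nitro at this place on the ring, ortho to a large group, leaves the number within the scatter in this assay (a 1.2-fold lower number from compound 1 to compound 4 (0.07 log units; within the scatter)), even though nitro brings more heavy atoms and adds hydrogen-bond acceptors. Within the data shown here, the 2-methylphenyl and 2-nitrophenyl rings therefore give matching results, which the earlier compounds could not show, since each of their steps changed both the group and its place on the ring. Compound 4 also relates to the other two compounds much as compound 1 does, with a rise from the 3-fluorophenyl ring (a 5.2-fold higher number from compound 2 to compound 4 (0.72 log units; beyond the scatter)) and a fall from the 3-(trifluoromethyl)phenyl ring (a 4.7-fold lower number from compound 3 to compound 4 (0.67 log units; beyond the scatter)), so the two rings named with a 3 remain on either side of this pair.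

Still open, on these data alone, is whether a 2-fluorophenyl or 3-nitrophenyl ring would follow its group or its place on the ring, and whether an amine or a carboxylic acid at the same carbon as the nitro would also match compound 1. Nothing given here accounts for why methyl and nitro match or why the other two rings differ so widely.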